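Adding a Second Methyl Group to Compound 2

The compounds below may be only part of what the source reports. "The series", "measured", "known", "first", "only" and "open" are said of these compounds alone.

Compound 1 `Cc1cccc(Nc2nc3cccnc3[se]2)c1`: 56400 nM
Compound 2 `Cc1ccc(Nc2nc3cccnc3[se]2)cc1`: 91500 nM

Of the compounds shown here, two have so far been measured in a functional assay on MCF7 cells (Homo sapiens) for cytotoxicity, read by MTT assay, with a stated time of 72 h; on this read-out higher numbers stand for weaker inhibition and lower numbers for stronger inhibition. Compound 1 `Cc1cccc(Nc2nc3cccnc3[se]2)c1` gives 56400 nM, and compound 2 `Cc1ccc(Nc2nc3cccnc3[se]2)cc1` gives 91500 nM. These two numbers lie within the usual scatter of each other, so neither compound can be set apart from the other. Compound 3 `Cc1ccc(Nc2nc3cccnc3[se]2)cc1C` differs from compound 2 by methyl in place of hydrogen on an aromatic carbon. Among the measured compounds shown here, no measured pair shows the effect of such a change here, so the step is expected to stay within the scatter, with no clear direction. The estimated step is a 1.2-fold lower number from compound 2 to compound 3 (0.09 log units; within the scatter). Compound 3 is expected to give 75000 nM in this assay, within a range of 25000 nM to 220000 nM.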

Compound 3, half-maximal inhibitory concentration: 202000 nM
Beside the measured number, compound 3's estimate is 2.7-fold (0.43 log units) below it; measured number inside the range.
By their numbers in this assay, from the lowest: compounds 1 and 2 (each within the scatter of the next); then compound 3.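

In this assay, methyl in place of hydrogen on this aromatic carbon, ortho to a methyl group and meta to a large group, gives a 2.2-fold higher number from compound 2 to compound 3 (0.34 log units; beyond the scatter) and so moves the read-out toward weaker inhibition, which the earlier pair could not show. Read the same way, the change gives a 3.6-fold higher number from compound 1 to compound 3 (0.55 log units; beyond the scatter) in the same direction. No available evidence bears on this result. From the compounds shown here alone, whether an ethyl group or a chlorine atom at this place would give a similar step stays open, as does whether an amine there would reverse it.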